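Changing the Amine on Compound 3

A few compounds are considered here, and "the series" means these few. Any claim that something is new, unique, unknown or untested is made for them only; others in the source may bear on it.

Within the data shown here, in a functional assay on MIA PaCa-2 cells (Homo sapiens) for inhibition, read by MTT assay, with a stated time of 48 h, tested at 10 uM (on this read-out higher numbers stand for more inhibition of growth at the one concentration tested and lower numbers for less inhibition of growth), compound 3 (`CCN(CC)Cc1c(O)c([C@H]2CCN(C)C[C@H]2O)c2oc(C)cc(=O)c2c1O`) gives 27% and stands highest of the three numbers so far. Compound 1 (`Cc1cc(=O)c2c(O)cc(OCc3ccc([N+](=O)[O-])cc3)c([C@H]3CCN(C)C[C@H]3O)c2o1`) at 12% and compound 2 (`Cc1cc(=O)c2c(O)cc(OCc3ccco3)c([C@H]3CCN(C)C[C@H]3O)c2o1`) at 7% both lie beyond the scatter below it. Compound 4 (`Cc1cc(=O)c2c(O)c(CN(C)CC(=O)O)c(O)c([C@H]3CCN(C)C[C@H]3O)c2o1`) keeps the shared core but carries (carboxymethyl)(methyl)amino in place of diethylamino on a saturated chain carbon bound to an aromatic carbon. Among the measured compounds shown here, the one measured step is a number 5 percentage points lower from compound 1 to compound 2 (within the scatter) and it involves another group at another place, so no measured step speaks directly to this change. In this assay no step beyond the scatter is therefore expected. The expected change is a number 9 percentage points lower from compound 3 to compound 4 (within the scatter) for now. Compound 4 is estimated at 18% with a likely range from 5% to 32% (an expectation, not a measurement).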

Compound 4, percent growth inhibition at one concentration: 16%
Estimate against measurement, compound 4: 2 percentage points above; measured number inside the range.
By their numbers in this assay, from the lowest: compounds 2, 1 and 4 (each within the scatter of the next); then compound 3.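

Among these compounds, this is the first measured change at this place, a saturated chain carbon bound to an aromatic carbon: in this assay, (carboxymethyl)(methyl)amino in place of diethylamino gives a number 11 percentage points lower from compound 3 to compound 4 (beyond the scatter) and so lies beyond the scatter. The group on this chain carbon can therefore shift growth inhibition, though the step is modest. No measurement shown gives a reason for the step.

Still open, from the compounds shown here alone, is which part of the entering group goes with the lower number. Dimethylamino, or the methyl ester of the carboxylic acid, at this same place would help separate those parts.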